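Quinoline substituent variation in the leukotriene ileum series

This account rests on a few compounds, and the source may have more. Where it says the series, first, only, none or still open, it means among the compounds named here.

Measured so far:
- compound 1 `CCC(CC)(CC(=O)Nc1cccc(OCc2ccc3c(F)cccc3n2)c1)C(=O)O`: 0.3 nM
- compound 2 `CCC(CC)(CC(=O)Nc1cccc(OCc2ccc3ccc(Cl)cc3n2)c1)C(=O)O`: 0.8 nM
- compound 3 `CCC(CC)(CC(=O)Nc1cccc(OCc2ccc3ccc(C(F)(F)F)cc3n2)c1)C(=O)O`: 3 nM

All three share the same core and are compared in a functional assay on ileum (Cavia porcellus) for antagonist activity at cysteinyl leukotriene receptor (Homo sapiens); a higher number here means a weaker inhibitor, a lower number a stronger inhibitor. Compound 3 gives the highest number of the three in this assay; its nearest neighbour is compound 2, and compound 1 stands furthest from it. Among the compounds with values here, the one step between two compounds that differ in a single place is a 3.8-fold higher number from compound 2 to compound 3 (0.57 log units; beyond the scatter).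

Compound 4 `CCC(CC)(CC(=O)Nc1cccc(OCc2ccc3ccc(C(C)=O)cc3n2)c1)C(=O)O` has not been measured. It differs from compound 3 in one place: acetyl in place of trifluoromethyl on an aromatic carbon. Within the data shown here, no measured step covers an acetyl group, so the only bearing comes from the step from compound 2 to compound 3, which moved the number modestly beyond the scatter when the substituent at the same place was exchanged. A step of broadly similar size, or none beyond the scatter, is therefore expected for a 1.7-fold higher number from compound 3 to compound 4 (0.22 log units; within the scatter), with the direction uncertain. Compound 4 is estimated at 5 nM in this assay, with a range from 1.5 nM to 15 nM.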

Compound 4, half-maximal inhibitory concentration: 2500 nM
Beside the measured number, compound 4's estimate is 500-fold (2.70 log units) below it; the whole stated range lies below it.
By their numbers in this assay, from the lowest: compound 1; then compound 2; then compound 3; then compound 4.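

In this assay acetyl in place of trifluoromethyl gives an 830-fold higher number from compound 3 to compound 4 (2.92 log units; beyond the scatter) and acetyl in place of chloro gives a 3100-fold higher number from compound 2 to compound 4 (3.49 log units; beyond the scatter) on the same aromatic carbon. The exchange of chloro for trifluoromethyl, a 3.8-fold higher number from compound 2 to compound 3 (0.57 log units; beyond the scatter) by comparison, gave no sign that this position could be so sensitive to its substituent, and the new change brings in a carbonyl with a hydrogen-bond acceptor that trifluoromethyl lacks. No measurement at hand bears on what lies behind this large step.

Going by these compounds, whether the carbonyl itself matters remains open, and a nitrile, a methoxy group or a hydroxyethyl group at this carbon would help to separate it from the rest of the acetyl group. Also open, on these data alone, is whether acetyl on another aromatic carbon of the shared core would give a step of similar size.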